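The source may report more compounds than this note shows. Statements on the series, on what has been measured and on what is new or still open speak of the compounds shown alone.

Series notes. In an assay on cells for inhibition of Palmitoleoyl-protein carboxylesterase NOTUM variant C330S (Homo sapiens), read by fluorescence, with a stated time of 40 min (on this read-out lower numbers stand for stronger inhibition and higher numbers for weaker inhibition), compound 1 `CNC(=O)C1CCN(c2ccc(Cl)c(C(F)(F)F)c2)C1` gives 1300 nM and compound 2 `O=C(Nc1ccccc1)C1CCN(c2ccc(Cl)c(C(F)(F)F)c2)C1` gives 1000 nM. Compound 2 stands lowest of the two numbers, with compound 1 nearest, and the step of a 1.3-fold lower number from compound 1 to compound 2 (0.11 log units; within the scatter) lies within the scatter. Compound 3 `CN(C)C(=O)C1CCN(c2ccc(Cl)c(C(F)(F)F)c2)C1` differs from compound 2 by dimethylamino in place of anilino on a carbonyl carbon. Going by the values given here, the only measured step that bears on this change is the one from compound 1 to compound 2, which stayed within the scatter, so for compound 3 no step beyond the scatter in this assay is expected in either direction. The estimate for compound 3 is 1500 nM, with a range of 600 nM to 4000 nM. This expected value corresponds to a 1.5-fold higher number from compound 2 to compound 3 (0.18 log units; within the scatter).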

Compound 3, half-maximal inhibitory concentration: 1200 nM
Beside the measured number, compound 3's estimate is 1.3-fold (0.10 log units) above it, and the stated range covers the measured number.
By their numbers in this assay, from the lowest: compounds 2, 3 and 1 (each within the scatter of the next).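

Working notes: in this assay the carbonyl carbon's amide substituent can lose the anilino group, with its aromatic ring and the amide hydrogen, without a step beyond the scatter (a 1.2-fold higher number from compound 2 to compound 3 (0.08 log units; within the scatter)). Methyl in place of the amide hydrogen of compound 1 likewise stays within the scatter (a 1.1-fold lower number from compound 1 to compound 3 (0.03 log units; within the scatter)), so across these three compounds neither the ring nor that hydrogen is required for this level of inhibition. Nothing measured explains this flat response.

Open, going by these compounds, is whether a carboxylic acid or a longer chain on the carbonyl carbon would move the number beyond the scatter. Also open, on these data alone, is whether replacing the carbonyl itself, for example with a sulfonamide, would do so.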